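The source may report more compounds than this note shows. Statements on the series, on what has been measured and on what is new or still open speak of the compounds shown alone.

Measured compounds:
compound 1, `COC(=O)CNc1cc(CS(=O)(=O)/C=C/c2c(OC)cc(OC)cc2OC)ccc1OC`, a functional assay on K562 cells (Homo sapiens) for cytotoxicity, read by trypan blue exclusion, with a stated time of 96 h; on this read-out higher numbers stand for weaker inhibition and lower numbers for stronger inhibition: 100 nM
compound 2, `COC(=O)CNc1cc(CS(=O)(=O)/C=C/c2cc(OC)c(OC)c(OC)c2)ccc1OC`, this assay: 30000 nM
compound 3, `COC(=O)C(Nc1cc(CS(=O)(=O)/C=C/c2c(OC)cc(OC)cc2OC)ccc1OC)c1ccc(OC)cc1`, this assay: 150 nM

Among these three, compound 1 holds the lowest number. Among the compounds with values here, its nearest neighbour is compound 3, and the step of a 1.5-fold higher number from compound 1 to compound 3 (0.18 log units; within the scatter) is the only single-point change in the set; the two compounds cannot be ordered against each other. Within the data shown here, compound 2 sits far off, its value and that of compound 1 being separated by a gap well beyond the scatter, but the two differ in the arrangement of the methoxy groups on the styryl ring, for which no step is recorded.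

Compound 4, `COc1cc(OC)c(/C=C/S(=O)(=O)Cc2ccc(OC)c(NC(C)(C)C(=O)O)c2)c(OC)c1`, has not been tested in this assay. It differs from compound 1 by 1-carboxy-1-methylethyl in place of (methoxycarbonyl)methyl on a nitrogen on an aromatic ring. Among the measured compounds shown here, no measured step covers an exchange of the ester for a carboxylic acid or the addition of the two methyl groups on the chain; the one step that touches this chain, compound 1 to compound 3, left the number where it was. With nothing to point either way, compound 4 is expected to come out near compound 1, with the uncertainty spread mostly toward higher numbers: a 2.5-fold higher number from compound 1 to compound 4 (0.40 log units; beyond the scatter). The estimate for compound 4 is therefore 250 nM, within 60 nM to 1500 nM.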

Compound 4, half-maximal inhibitory concentration: 7.5 nM
The estimate for compound 4 lay 33-fold (1.52 log units) above the measured number, and the stated range ends above it.
By their numbers in this assay, from the lowest: compound 4; then compounds 1 and 3 (each within the scatter of the next); then compound 2.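

In this assay, the group on the nitrogen on an aromatic ring proves able to move the number a long way: replacing (methoxycarbonyl)methyl with 1-carboxy-1-methylethyl gives a 13-fold lower number from compound 1 to compound 4 (1.12 log units; beyond the scatter). The only earlier step at this place, a 1.5-fold higher number from compound 1 to compound 3 (0.18 log units; within the scatter), had shown no change that could be told from the scatter, so that step gave no sign of how much the number could respond to a change on this chain. The measurements show the size and direction of this one exchange, but nothing offered here explains it.

The exchange turns the methyl ester into a carboxylic acid and adds two methyl groups to the chain at once, so the compounds shown leave open how much of the step belongs to each; the carboxymethyl group and the methyl ester of the branched chain would separate the two. Also open, as far as these compounds go, are whether an amide or a longer chain bearing a carboxylic acid would serve on this nitrogen, and whether 1-carboxy-1-methylethyl would lower the number on the core of compound 2 as well.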